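Swapping the amide ring while keeping the fluoromethyl chain

The source may hold more compounds than are shown below. What is called first, only, known or untested is meant among the compounds shown, and "the series" means these compounds.

Four compounds share one core and differ in the ring attached to the amide carbonyl and in a short side chain. Compound 1 `C[C@@]1(c2cc(NC(=O)c3coc(C(F)F)n3)ccc2F)C=C(CF)OC(N)=N1` gives 2.6 in a physicochemical assay for lipophilicity, read by HPLC, in phosphate buffer, measured as octanol-water partition, with a stated time of 1 h, at pH 7.4; a lower number here means a more polar compound, a higher number a more lipophilic compound. Compound 2 `C[C@@]1(c2cc(NC(=O)c3coc(CF)n3)ccc2F)C=C(CF)OC(N)=N1` gives 2.2 in this assay, the second highest of the three numbers. Compound 3 `COCC1=C[C@@](C)(c2cc(NC(=O)c3ccc(C#N)cn3)ccc2F)N=C(N)O1` gives 2, within the scatter of compound 2. Going by the values given here, the only single-point step known is a number 0.40 log units lower from compound 1 to compound 2 (beyond the scatter), and it concerns the chain on the oxazole, not the change now considered. Compound 4 `C[C@@]1(c2cc(NC(=O)c3ccc(C#N)cn3)ccc2F)C=C(CF)OC(N)=N1` has not yet been measured; it differs from compound 2 in this way: 5-cyanopyridin-2-yl in place of 2-(fluoromethyl)-1,3-oxazol-4-yl on a carbonyl carbon. Among the compounds with values here, no measured pair isolates this exchange. Compound 3 carries the same 5-cyanopyridin-2-yl group and sits close to compound 2, so little movement is expected. Compound 4 is therefore estimated at 2.1, with a likely range from 1.7 to 2.5. The expected step is a number 0.10 log units lower from compound 2 to compound 4 (within the scatter), within the scatter.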

Compound 4, distribution coefficient: 2.3
Compound 4: middle estimate off by 0.20 log units, on the low side, and the stated range covers the measured number.
By their numbers in this assay, from the lowest: compounds 3, 2, 4 and 1 (each within the scatter of the next, the first and the last beyond it).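

Putting 5-cyanopyridin-2-yl in place of 2-(fluoromethyl)-1,3-oxazol-4-yl on the carbonyl carbon gives in this assay a number 0.10 log units higher from compound 2 to compound 4 (within the scatter) and, in place of 2-(difluoromethyl)-1,3-oxazol-4-yl, a number 0.30 log units lower from compound 1 to compound 4 (within the scatter) so neither exchange at this position can be told apart from repeat-measurement noise. Going by these compounds alone, the side chain adds a second such case: fluoro in place of methoxy on the saturated chain carbon bound to a double-bonded ring carbon gives a number 0.30 log units higher from compound 3 to compound 4 (within the scatter) and this is the first look at that change. No measurement shown explains these numbers.

As far as these compounds go, whether the fluoro-for-methoxy result would hold with an oxazole ring on the carbonyl carbon remains open. So does how this assay would respond to an amine or a carboxylic acid in place of the nitrile.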